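Oxadiazoline series: swapping the aryl group at the saturated carbon

The source may hold more compounds than are shown below. What is called first, only, known or untested is meant among the compounds shown, and "the series" means these compounds.

Measured so far in a functional assay on PC-3 cells (Homo sapiens) for antiproliferative activity, read by MTT assay, tested at 1 uM; a higher number here means a stronger effect of the compound at the concentration tested, a lower number a weaker effect:
- compound 1, `COc1cc(C2=NN(C(C)=O)C(c3c(Cl)cccc3Cl)O2)cc(OC)c1OC`: 5.1%
- compound 2, `COc1cc(C2=NN(C(C)=O)C(c3cc(Cl)cc(Cl)c3)O2)cc(OC)c1OC`: 52.7%
- compound 3, `COc1cc(C(=O)N/N=C/c2cccc(F)c2)cc(OC)c1OC`: 53.5%

Compound 2 stands second highest of the three numbers. Its nearest neighbour is compound 3, whose value lies within the scatter of that of compound 2, so no order between the two is claimed. Compound 1 lies far lower, beyond the scatter.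

The next compound is compound 4, `COc1cc(C2=NN(C(C)=O)C(c3cccc(OC)c3OC)O2)cc(OC)c1OC`. It differs from compound 2 in one place: 2,3-dimethoxyphenyl in place of 3,5-dichlorophenyl on a saturated ring carbon.

Within the data shown here, the only step that bears on this position is a number 47.6 percentage points higher from compound 1 to compound 2 (beyond the scatter), which shows that the substitution pattern on the aryl ring at the saturated ring carbon moves this assay strongly. Among the measured compounds shown here, that step swapped chlorine positions only; no measured pair exchanges chlorine for methoxy, so the direction for compound 4 is not fixed by the data. Given the sensitivity of this position, a step of either sign beyond the scatter is plausible; a downward step is taken as the more likely expectation, a number 22.7 percentage points lower from compound 2 to compound 4 (beyond the scatter).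

Compound 4 is therefore estimated at 30% in this assay, with a range from 5% to 60%.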

Compound 4, a percentage reported as inhibition, at one concentration (the size of the read-out at that concentration, not a potency): 35%
Compound 4: middle estimate off by 5 percentage points, on the low side, within the range that was stated.
By their numbers in this assay, from the lowest: compound 1; then compound 4; then compounds 2 and 3 (each within the scatter of the next).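

In this assay, among these compounds, the exchange of chlorine for methoxy at the saturated ring carbon can now be read for the first time, and the outcome depends on the dichlorophenyl isomer taken as reference: a number 17.7 percentage points lower from compound 2 to compound 4 (beyond the scatter), whereas a number 29.9 percentage points higher from compound 1 to compound 4 (beyond the scatter). Compound 4 therefore sits between the two dichlorophenyl compounds, which shows that a 2,3-dimethoxyphenyl group keeps part of the read-out and that the level at this position is not tied to chlorine alone. No evidence is available to explain these differences.

The compounds shown do not separate the kind of substituent from its placement on the aryl ring, as a 3,5-dimethoxyphenyl group at this carbon would. From the compounds shown here alone, it also remains open how an aryl ring carrying an amine or a carboxylic acid would compare here.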